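Esterifying the second acid of compound 1

This account rests on a few compounds, and the source may have more. Where it says the series, first, only, none or still open, it means among the compounds named here.

Compound 1, `CCCc1nc(C(C)(C)O)c(C(=O)O)n1Cc1ccc(-c2ccccc2C(=O)O)cc1`, carries two free carboxylic acid groups. In a functional assay on the whole organism for inhibition, with Rattus norvegicus as the target, with a stated time of 6 h, at a dose of 1 mg/kg (a higher number here means more inhibition at the dose given (going by the name of the read-out), a lower number less inhibition), compound 1 gives 12%, the lower of the two numbers measured, the other belonging to compound 2. Compound 2, `CCCc1nc(C(C)(C)O)c(C(=O)OCOC(=O)OC(C)C)n1Cc1ccc(-c2ccccc2C(=O)O)cc1`, gives 71% in this assay. Among the compounds with values here, the single measured step, a number 59 percentage points higher from compound 1 to compound 2 (beyond the scatter), shows that placing a ((isopropoxycarbonyl)oxy)methyl group on an oxygen next to a carbonyl group raised inhibition strongly.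

Compound 3, `CCCc1nc(C(C)(C)O)c(C(=O)O)n1Cc1ccc(-c2ccccc2C(=O)OCOC(=O)C(C)(C)C)cc1`, has not been measured. It differs from compound 1 by (((tert-butyl)carbonyl)oxy)methyl in place of hydrogen on an oxygen next to a carbonyl group. The change is of the same kind as that in the measured step, an acyloxymethyl-type group entering on an oxygen next to a carbonyl group, though here on the other carboxylic acid of the shared core and with a different acyl part. Within the data shown here, because of a number 59 percentage points higher from compound 1 to compound 2 (beyond the scatter) a rise of similar direction is expected for compound 3, though its size is uncertain, since only one comparable step exists. The expected step is a number 43 percentage points higher from compound 1 to compound 3 (beyond the scatter). Compound 3 is therefore estimated to give 55% in this assay, within a range of 25% to 80%.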

Compound 3, a percentage reported as inhibition, in the whole organism at one dose (the size of the read-out at that dose, not a potency): 40%
Compound 3: the middle estimate sits 15 percentage points above what was measured; the measured number falls inside the stated range.
By their numbers in this assay, from the lowest: compound 1; then compound 3; then compound 2.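

In this assay, the other carboxylic acid of compound 1 also responds to this kind of change: with (((tert-butyl)carbonyl)oxy)methyl in place of hydrogen on an oxygen next to a carbonyl group, the result is a number 28 percentage points higher from compound 1 to compound 3 (beyond the scatter). The rise is therefore not confined to one of the two acids, although this modest step stands beside the large one seen earlier, a number 59 percentage points higher from compound 1 to compound 2 (beyond the scatter), and the two changes differ both in which acid is capped and in the group that enters, so neither difference can be credited alone. Nothing at hand bears on the cause of either rise.

The compounds shown leave open how each group would read on the acid carrying the other, which is what would separate the effect of the place from that of the group, and what a compound with such a group on both acids would give. They also say nothing about whether an ethyl ester or an amide on either acid would raise the number in this assay.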